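A few compounds are considered here, and "the series" means these few. Any claim that something is new, unique, unknown or untested is made for them only; others in the source may bear on it.

In an assay on isolated protein for inhibition of phosphatidylinositol 4,5-bisphosphate 3-kinase catalytic subunit beta isoform (Homo sapiens) (a lower number here means a stronger inhibitor, a higher number a weaker inhibitor), three compounds have been measured. Compound 1 `COc1ccc(-c2ccnc(Nc3ccc(Cl)cc3Cl)n2)cc1` gives 839 nM in this assay, and compound 2 `Clc1ccc(Nc2nccc(-c3ccc(Br)cc3)n2)c(Cl)c1` gives 673 nM. Among the measured compounds shown here, the single change between them is bromo in place of methoxy on an aromatic carbon, and it made the step of a 1.2-fold lower number from compound 1 to compound 2 (0.10 log units; within the scatter). Compound 3 `COc1ccc(-c2ccnc(Nc3cccc(OC)c3)n2)cc1` gives 729 nM in this assay; how its core differs from the core of compound 1 is not broken down here, and its value lies within the scatter of both compound 1 and compound 2, so no order can be read among the three.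

Compound 4 `COc1cccc(Nc2nccc(-c3ccc(Br)cc3)n2)c1` has not yet been measured in this assay. It differs from compound 3 by bromo in place of methoxy on an aromatic carbon, which is the same change that turns compound 1 into compound 2, made at the same kind of place. Because that earlier change gave only a 1.2-fold lower number from compound 1 to compound 2 (0.10 log units; within the scatter), the step expected here is a 1.2-fold lower number from compound 3 to compound 4 (0.07 log units; within the scatter), resting on that one precedent. Compound 4 is therefore estimated at 620 nM in this assay, with the likely range running from 300 nM to 1300 nM.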

Compound 4, half-maximal inhibitory concentration: 977 nM
The estimate for compound 4 lay 1.6-fold (0.20 log units) below the measured number; the measured number falls inside the stated range.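

In this assay, bromo in place of methoxy on an aromatic carbon, para to a large group, gave a 1.3-fold higher number from compound 3 to compound 4 (0.13 log units; within the scatter). Set beside the same change on the core of compound 1, the new step does not differ from the earlier one: the same change on two cores in this assay, a 1.2-fold lower number (0.10 log units; within the scatter) from compound 1 to compound 2 and a 1.3-fold higher number (0.13 log units; within the scatter) from compound 3 to compound 4, 1.7-fold (0.22 log units) apart, within the scatter of two such steps. On these two cores the change therefore carries over as a step within the scatter, and the opposite directions of the two steps cannot be read as a real difference between the cores, though two small steps do not show that the change would behave the same way on any other core in the series.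

The compounds shown hold only methoxy and bromo at this place, so it remains open what an amine, a carboxylic acid or a longer chain would do there. As far as these compounds go, it is equally open whether any group at this place could move the number beyond the scatter in either direction.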